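Methyl added to the aryl group of compound 1

The source may report more compounds than this note shows. Statements on the series, on what has been measured and on what is new or still open speak of the compounds shown alone.

Measured so far in an ADME assay on HepG2 2.2.15 cells (Homo sapiens) for cytotoxicity, read by CCK-8 assay, with a stated time of 8 days; on this read-out higher numbers stand for lower toxicity in this test and lower numbers for higher toxicity in this test:
- compound 1 `COc1ccc(C(=O)Nc2c[nH]c(=O)c(-c3cccc(C)c3)c2)c(O)c1` gives > 100000 nM, a limit
- compound 2 `Cc1cccc(-c2cc(NC(=O)c3ccc(F)cc3O)c[nH]c2=O)c1` gives 37200 nM

The reading of compound 1 is the limit of > 100000 nM in this assay, at which 1 of the 2 values shown sits, a limit and not a number. Any step starting from compound 1 is therefore only bounded on one side.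

Compound 3 `COc1ccc(C(=O)Nc2c[nH]c(=O)c(-c3cc(C)ccc3C)c2)c(O)c1` differs from compound 1 by one change, methyl in place of hydrogen on an aromatic carbon, which turns 3-methylphenyl into 2,5-dimethylphenyl.

Among the compounds with values here, no measured step covers this change. Within the data shown here, the only step available is an at least 2.6-fold lower number from compound 1 to compound 2 (0.42 log units; beyond the scatter), and it replaces methoxy with fluoro elsewhere in the molecule. It shows that a single substitution on compound 1 can bring a number into range, but it says nothing direct about methyl. A small step toward lower numbers is expected in this assay, or none beyond the scatter, and compound 3 may well report as a limit too.

The estimated step is an at least 1.1-fold lower number from compound 1 to compound 3 (0.04 log units; that floor lies within the scatter). For compound 3 the expected value is 90000 nM, with an estimated range from 40000 nM to 200000 nM.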

Compound 3, half-maximal cytotoxic concentration: 50400 nM
Beside the measured number, compound 3's estimate is 1.8-fold (0.25 log units) above it; the measured number falls inside the stated range.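

In this assay, methyl in place of hydrogen on an aromatic carbon, ortho to a large group and para to a methyl group, gives an at least 1.9-fold lower number from compound 1 to compound 3 (0.29 log units; that floor lies within the scatter). Within the data shown here, until now the only reading on compound 1 came from replacing methoxy with fluoro, so this is the first sign that a change on the 3-methylphenyl group, here to 2,5-dimethylphenyl, can also bring a number into range, though the floor of the step does not clear the scatter. Compound 1 reports a limit and not a number, so the step is bounded on one side only and its true size may be larger: the limit of > 100000 nM in this assay, at which 1 of the 3 values shown sits.

As far as these compounds go, it remains open whether another group at this place, such as an amine, a carboxylic acid or a longer chain, would move the number in the same direction as methyl. Also open, from the compounds shown here alone, is whether the same methyl gives a similar step on compound 2, where the starting point is a number and not a limit, so that the size of the step could be read in full.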